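Benzoxazole sulfonamides: moving the fluorine on the sulfonyl aryl

A few compounds are considered here, and "the series" means these few. Any claim that something is new, unique, unknown or untested is made for them only; others in the source may bear on it.

Measured compounds:
compound 1 `O=S(=O)(Nc1ccc(-c2nc3ccccc3o2)cc1)c1cccc(F)c1` in an assay on cells for inhibition of HSP60/HSP10 (Homo sapiens), with a stated time of 60 min (on this read-out higher numbers stand for weaker inhibition and lower numbers for stronger inhibition), compound 1 gives 71000 nM
compound 2 `Cc1ccc(S(=O)(=O)Nc2ccc3oc(-c4ccccc4)nc3c2)cc1` in this assay compound 2 gives > 100000 nM, a limit of the assay
compound 3 `Cc1ccccc1S(=O)(=O)Nc1ccc2oc(-c3ccccc3)nc2c1` in this assay compound 3 gives > 100000 nM, a limit of the assay

Within the data shown here, compound 1 holds the only number in this assay; the other two values are limits. Among the measured compounds shown here, the one step between measured compounds, a step that the two limits leave unreadable from compound 2 to compound 3, is not readable in size because of the limit of > 100000 nM in this assay, at which 2 of the 3 values shown sit.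

Compound 4 `O=S(=O)(Nc1ccc(-c2nc3ccccc3o2)cc1)c1ccccc1F` is not yet measured. It differs from compound 1 by 2-fluorophenyl in place of 3-fluorophenyl on a sulfonyl sulfur. For the measured compounds named here, no measured step bears directly on this change: the only step on record moves a methyl on the sulfonyl aryl and cannot be read. Compound 1 therefore sets the expectation, and a step of a 1.1-fold higher number from compound 1 to compound 4 (0.05 log units; within the scatter) is expected, which is no change beyond the scatter. The value for compound 4 in this assay is estimated at 80000 nM, with a range from 30000 nM to 200000 nM.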

Compound 4, half-maximal inhibitory concentration: > 100000 nM
Compound 4: no number, only a limit; the forecaster's own chance of this, stated with the estimate: 35%; at least 1.2-fold (0.09 log units) between middle value and limit.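

In this assay compound 4 gives > 100000 nM, which is a limit of the assay and not a number. Among these compounds, this gives the first comparison on the sulfonyl aryl with a number on one side, a shift of the fluorine from 3-fluorophenyl to 2-fluorophenyl: an at least 1.4-fold higher number from compound 1 to compound 4 (0.14 log units; that floor lies within the scatter). That floor does not establish a loss beyond the usual scatter, and the true size of the step stays unread because of the limit: the limit of > 100000 nM in this assay, at which 3 of the 4 values shown sit.

Still open, on these data alone, is whether an amine or a carboxylic acid in place of the fluorine, or a plain phenyl on the sulfonyl sulfur, would give a number rather than a limit. Among the compounds shown here, with compound 1 still the only compound holding a number, no trend around it can yet be read.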